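Working notes: from compound 2 to compound 4

The source may report more compounds than this note shows. Statements on the series, on what has been measured and on what is new or still open speak of the compounds shown alone.

Measured so far:
compound 1 `Cc1cc(C)cc(Nc2nccc(-c3ccccn3)n2)c1` — 100 nM
compound 2 `CCOC(=O)C(=O)N(c1ccccc1)c1nccc(-c2ccncc2)n1` — 2200 nM
compound 3 `CC(=O)Nc1ccc(Nc2nccc(-c3cccnc3)n2)cc1` — 3600 nM

Three compounds have numbers in a functional assay for inhibition, with Homo sapiens as the target; on this read-out lower numbers stand for stronger inhibition and higher numbers for weaker inhibition. Compound 2 gives 2200 nM, the second highest of the three. Compound 3 gives 3600 nM, a gap to compound 2 that lies within the usual scatter, so no order is drawn between these two. Compound 1 gives 100 nM, a gap to compound 2 that lies beyond the scatter; compound 2 is the weaker inhibitor of that pair. Among the compounds with values here, the three compounds differ from one another in more than one place, so no single step between them can be read off.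

Compound 4 `CN(c1ccccc1)c1nccc(-c2ccncc2)n1` has not been measured. It differs from compound 2 in one place: methyl in place of (ethoxycarbonyl)carbonyl on a nitrogen on an aromatic ring. Within the data shown here, no measured pair changes this position, so the expectation rests on compound 2 alone. The step in this assay from compound 2 to compound 4 is expected to be modest, perhaps toward a lower number, estimated as a 1.8-fold lower number from compound 2 to compound 4 (0.26 log units; within the scatter). Compound 4 is estimated at 1200 nM, with a range from 300 nM to 5000 nM.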

Compound 4, half-maximal inhibitory concentration: > 24000 nM
Compound 4 ended at the assay's limit; the forecaster's own chance of this, stated with the estimate: 5%; at least 20-fold (1.30 log units) between middle value and limit.
By their numbers in this assay, from the lowest: compound 1; then compounds 2 and 3 (each within the scatter of the next). At a limit, above all of these: compound 4.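

In this assay compound 4 gives > 24000 nM, which is a limit of the assay and not a number: the limit of > 24000 nM in this assay, at which 1 of the 4 values shown sits. Methyl in place of (ethoxycarbonyl)carbonyl on a nitrogen on an aromatic ring gives an at least 10-fold higher number from compound 2 to compound 4 (1.03 log units; beyond the scatter), the first step that can be read at this position. What sits on this nitrogen therefore matters in this assay, and the pair shows that methyl does not keep the inhibition seen with (ethoxycarbonyl)carbonyl.

The compounds shown leave open which part of the (ethoxycarbonyl)carbonyl group carries the difference, since only this one replacement is available at this position. As far as these compounds go, whether an acetyl group, a carboxylic acid or a longer alkyl chain such as propyl on this nitrogen would stay near compound 2 or near compound 4 remains open.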